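The source may report more compounds than this note shows. Statements on the series, on what has been measured and on what is new or still open speak of the compounds shown alone.

In an ADME assay on microsomes from liver (Mus musculus) for metabolic stability, read by LC-MS, with a stated time of 40 min, tested at 0.5 uM (on this read-out lower numbers stand for slow clearance and higher numbers for fast clearance), compound 1 (`CC(C)(C)NS(=O)(=O)c1cccc(NC(=O)c2ccc(NC(C)(C)CO)cc2N2CCC3(CC2)CC3)n1`) gives > 399 mL.min-1.g-1, which is a limit of the assay and not a number. Compound 2 (`CC(C)(O)CNc1ccc(C(=O)Nc2cccc(S(=O)(=O)C3CCCC3)n2)c(N2CCC3(CC2)CC3)c1`) gives > 399 mL.min-1.g-1, which is also a limit. Compound 2 and compound 1 therefore share (the limit of > 399 mL.min-1.g-1 in this assay, at which 2 of the 2 values shown sit). Compound 3 (`COc1ccc(C(=O)Nc2cccc(S(=O)(=O)C3CCCC3)n2)c(N2CCC3(CC2)CC3)c1`) carries methoxy in place of (2-hydroxy-2-methylpropyl)amino on an aromatic carbon, para to a large group: methoxy in place of (2-hydroxy-2-methylpropyl)amino on an aromatic carbon. Within the data shown here, no measured step shows what such a change does, so only a modest fall is expected, an estimated at least 1.4-fold lower number from compound 2 to compound 3 (0.15 log units; that floor lies within the scatter). Compound 3 is estimated at 280 mL.min-1.g-1, with an expected range of 120 mL.min-1.g-1 to 399 mL.min-1.g-1.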

Compound 3, intrinsic clearance in microsomes: > 399 mL.min-1.g-1
Compound 3 ended at the assay's limit; the forecaster's own chance of this, stated with the estimate: 40%; middle value at least 1.4-fold (0.15 log units) away from the limit.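

Compound 2 and compound 3 both end at a limit of the assay rather than a number, so swapping (2-hydroxy-2-methylpropyl)amino for methoxy gives no readable step: the limit of > 399 mL.min-1.g-1 in this assay, at which 3 of the 3 values shown sit.

What stays open is how far the true clearance of these compounds lies past that limit, and whether the two groups differ at all.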